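Glucosyl enone thioureas: a nitro-methoxyphenyl variant assessed for tolerance

The source may hold more compounds than are shown below. What is called first, only, known or untested is meant among the compounds shown, and "the series" means these compounds.

Of the compounds shown here, two sharing a peracetylated glucosyl enone core have been measured in an ADME assay on Vero cells (Chlorocebus sabaeus) for cytotoxicity, read by resazurin assay, with a stated time of 2 days; a higher number here means that more compound is tolerated, a lower number that less compound is tolerated. Compound 1 `CC(=O)OC[C@H]1O[C@@H](CC(=O)/C=C/c2cccc(NS(=O)(=O)c3ccc(C)cc3)c2)[C@H](OC(C)=O)[C@@H](OC(C)=O)[C@@H]1OC(C)=O` carries a tosyl sulfonamide on the aryl nitrogen, and in this assay compound 1 gives 584000 nM. Compound 2 `CC(=O)OC[C@H]1O[C@@H](CC(=O)/C=C/c2cccc(NC(=S)Nc3ccccc3)c2)[C@H](OC(C)=O)[C@@H](OC(C)=O)[C@@H]1OC(C)=O` replaces that group with a phenylthiourea, and in this assay compound 2 gives 337000 nM. Among the measured compounds shown here, the only step between them, a 1.7-fold lower number from compound 1 to compound 2 (0.24 log units; within the scatter), leaves the two values within the scatter of each other, so compound 2 stands alongside compound 1 rather than apart from it.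

Compound 3 `COc1cc([N+](=O)[O-])ccc1NC(=S)Nc1cccc(/C=C/C(=O)C[C@@H]2O[C@H](COC(C)=O)[C@@H](OC(C)=O)[C@H](OC(C)=O)[C@H]2OC(C)=O)c1` differs from compound 2 by 2-methoxy-4-nitrophenyl in place of phenyl on an amide-type nitrogen. For the measured compounds named here, no measured step touches the substitution pattern of this phenyl ring; the single step available, from the sulfonamide to the thiourea, altered a larger part of the molecule and still produced no change beyond the scatter. A decorated phenyl on the thiourea is therefore expected to give at most a modest shift, with no clear direction, in this assay; the estimated step of a 1.3-fold lower number from compound 2 to compound 3 (0.13 log units; within the scatter) is accordingly small. For compound 3 the estimate in this assay is 250000 nM, with a range from 90000 nM to 650000 nM.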

Compound 3, half-maximal cytotoxic concentration: 559000 nM
Compound 3: the middle estimate sits 2.2-fold (0.35 log units) below what was measured; the range from low to high includes it.
By their numbers in this assay, from the lowest: compounds 2, 3 and 1 (each within the scatter of the next).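

In this assay, putting 2-methoxy-4-nitrophenyl in place of phenyl on the amide-type nitrogen gives a 1.7-fold higher number from compound 2 to compound 3 (0.22 log units; within the scatter). This position, which carries a plain phenyl in compound 2, thus takes a group of 11 heavy atoms in place of one of 6, with a methoxy and a nitro added, and the reading stays within the scatter. Compound 2, compound 3 and compound 1 now each lie within the scatter of the next, so neither this change nor the earlier exchange of the sulfonamide for the thiourea separates the compounds in this assay, and no evidence bearing on this result is at hand.

Going by these compounds, the step brings in the methoxy and the nitro together, and what each of them does alone stays open. Also open, on these data alone, is how this assay would read with an amine or a carboxylic acid on that phenyl, or with a longer chain in place of the phenyl on the amide-type nitrogen.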